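Swapping isopropyl for methyl on an amide nitrogen

This account rests on a few compounds, and the source may have more. Where it says the series, first, only, none or still open, it means among the compounds named here.

Compound 1 `CC(C)c1cc(C(=O)N(C)c2ccc(NC(=O)CCCCCCCC(=O)NO)cc2)c(O)cc1O`: 400 nM
Compound 2 `CC(C)c1cc(C(=O)N(c2ccc(NC(=O)CCCCCCC(=O)NO)cc2)C(C)C)c(O)cc1O`: > 10000 nM (a limit, not a number)

In a functional assay on NCI-H1975 cells (Homo sapiens) for inhibition, read by sulforhodamine B assay, with a stated time of 48 h (on this read-out higher numbers stand for weaker inhibition of growth and lower numbers for stronger inhibition of growth), compound 1 gives 400 nM as its measured value. Compound 2 reads > 10000 nM as a limit of the assay, so it has no exact number. Compound 3 `CC(C)c1cc(C(=O)N(C)c2ccc(NC(=O)CCCCCCC(=O)NO)cc2)c(O)cc1O` is compound 2 with methyl in place of isopropyl on an amide-type nitrogen and still awaits measurement. Within the data shown here, no measured pair shows this change on its own, so any forecast is uncertain. Compound 1 also carries methyl on that nitrogen and gives 400 nM as its value, so a large move toward stronger inhibition of growth is expected for compound 3 in this assay as well. The expected change is an at least 12-fold lower number from compound 2 to compound 3 (1.09 log units; beyond the scatter) and would lie well beyond the usual scatter. For compound 3 the estimated value is 800 nM with 200 nM to 4000 nM as the expected range.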

Compound 3, concentration for 50% growth inhibition: 690 nM
For compound 3 the middle estimate is 1.2-fold (0.06 log units) above the measured one; low and high end bracket the measured number.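

In this assay, the two groups on the amide-type nitrogen can now be compared with the rest of the structure unchanged: methyl in place of isopropyl gives an at least 14-fold lower number from compound 2 to compound 3 (1.16 log units; beyond the scatter), a large step. This step is only a minimum size, because compound 2 stands at a limit and has no exact number: the limit of > 10000 nM in this assay, at which 1 of the 3 values shown sits. With methyl on that nitrogen, hydroxycarbamoyl in place of (hydroxycarbamoyl)methyl gives a 1.7-fold higher number from compound 1 to compound 3 (0.24 log units; within the scatter), so this chain change stays within the usual scatter, unlike the change on the nitrogen.

The compounds shown leave open how growth inhibition responds to ethyl or to a plain hydrogen on that nitrogen. They also leave open whether isopropyl on that nitrogen would behave the same way with the longer chain of compound 1.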